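The source may hold more compounds than are shown below. What is called first, only, known or untested is meant among the compounds shown, and "the series" means these compounds.

The measured compounds:

compound 1 `Cc1c(-c2ccccc2)cc(-c2ccccc2)n1CCCCCCNC(=O)Oc1ccccc1`, 460 nM
compound 2 `O=C(NCCCCCCn1c(-c2ccccc2)cc2ccccc21)Oc1ccccc1`, 520 nM
compound 3 `O=C(NCCCCCCn1c(-c2ccccc2)c(-c2ccccc2)c2ccccc21)Oc1ccccc1`, 4700 nM

In an assay on microsomes from brain (strain Sprague-Dawley) for inhibition of Fatty-acid amide hydrolase 1 (Rattus norvegicus), read by fluorescence and HPLC, with stated times of 10 min and 60 min (on this read-out higher numbers stand for weaker inhibition and lower numbers for stronger inhibition), compound 1 gives 460 nM, the lowest of the three numbers. Compound 2 gives 520 nM, within the scatter of compound 1, so the two cannot be ordered. Compound 3 gives 4700 nM, beyond the scatter above both.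

Compound 4 `Cc1ccc(-c2ccccc2)n1CCCCCCNC(=O)Oc1ccccc1` differs from compound 1 by hydrogen in place of phenyl on an aromatic carbon. Within the data shown here, the only measured step that bears on this is a 9.0-fold higher number from compound 2 to compound 3 (0.96 log units; beyond the scatter), where a phenyl was added to an aromatic carbon of a different core and the number rose. Read in reverse, removing a phenyl would be expected to lower the number. Against that, compound 1, which already carries the phenyl, sits within the scatter of compound 2, which lacks an added phenyl, so on the core of compound 1 the phenyl does not appear to cost anything. The two readings point in different directions, and a step of modest size at most is expected for compound 4, a 1.5-fold lower number from compound 1 to compound 4 (0.19 log units; within the scatter), possibly none beyond the scatter.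

Compound 4 is therefore expected to give 300 nM in this assay, with a range of 100 nM to 1200 nM.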

Compound 4, half-maximal inhibitory concentration: 310 nM
For compound 4 the middle estimate is 1.0-fold (0.01 log units) below the measured one; measured number inside the range.
By their numbers in this assay, from the lowest: compounds 4, 1 and 2 (each within the scatter of the next); then compound 3.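

On the core of compound 1, replacing the phenyl with hydrogen on the aromatic carbon next to the ring atom that bears a methyl group gives a 1.5-fold lower number from compound 1 to compound 4 (0.17 log units; within the scatter) in this assay, so this phenyl can be removed with no change that can be told from the scatter. Among these compounds, compound 4 also shows that the phenyl on this carbon of the core of compound 1 is neither needed for inhibition at this level nor a measurable burden, which the earlier compounds could only suggest indirectly. The large step seen on the other core therefore does not carry over, and the same change reads differently on the two cores: the same change on two cores in this assay, a 9.0-fold higher number (0.96 log units; beyond the scatter) from compound 2 to compound 3 and a 1.5-fold higher number (0.17 log units; within the scatter) from compound 4 to compound 1, 6.1-fold (0.78 log units) apart, beyond the scatter of two such steps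

The compounds shown leave open whether a different group on this aromatic carbon, such as a methoxy group, a chlorine atom or a pyridine ring, would move the number beyond the scatter in either direction on the core of compound 4. They also do not tell why the two cores differ, or what the methyl group and the remaining phenyl contribute on the core of compound 4.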